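Naphthalen-1-yl in place of 4-bromophenyl on the thioether arm

A few compounds are considered here, and "the series" means these few. Any claim that something is new, unique, unknown or untested is made for them only; others in the source may bear on it.

Measured compounds in a functional assay on PC-9 cells (Homo sapiens) for inhibition, read by MTT assay, with a stated time of 72 h; on this read-out higher numbers stand for weaker inhibition and lower numbers for stronger inhibition:
- compound 1 `Cc1cc(Nc2cc(-c3ccccc3)[nH]n2)n2nc(SCc3ccc([N+](=O)[O-])cc3)nc2n1`: 7980 nM
- compound 2 `Cc1cc(Nc2cc(-c3ccccc3)[nH]n2)n2nc(SCc3ccc(Br)cc3)nc2n1`: 4760 nM
- compound 3 `Cc1cc(Nc2cc(-c3ccccc3)[nH]n2)n2nc(SCc3ccccc3Br)nc2n1`: 5630 nM

Compound 2 gives the lowest of the three numbers in this assay, but the gaps to its neighbours are small: a 1.2-fold higher number from compound 2 to compound 3 (0.07 log units; within the scatter) and a 1.7-fold lower number from compound 1 to compound 2 (0.22 log units; within the scatter), both within the scatter, so no ordering among compounds 1, 2 and 3 can be claimed. The step from compound 1 to compound 3 is likewise within the scatter a 1.4-fold lower number from compound 1 to compound 3 (0.15 log units; within the scatter). Across the three, the group on the saturated chain carbon bound to the sulfur has been varied without any shift beyond the scatter.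

Compound 4 `Cc1cc(Nc2cc(-c3ccccc3)[nH]n2)n2nc(SCc3cccc4ccccc34)nc2n1` continues this variation: naphthalen-1-yl in place of 4-bromophenyl on a saturated chain carbon bound to a sulfur. The three measured steps all concern the same position and all lie within the scatter, which is the only bearing they have. Going by the values given here, no measured step introduces a second aromatic ring at this position, so the expectation rests on the flatness seen so far. In this assay compound 4 is therefore expected to give 5000 nM, with a range from 2000 nM to 12500 nM. The expected step is a 1.1-fold higher number from compound 2 to compound 4 (0.02 log units; within the scatter), with no direction beyond the scatter anticipated.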

Compound 4, half-maximal inhibitory concentration: 3950 nM
Beside the measured number, compound 4's estimate is 1.3-fold (0.10 log units) above it; the measured number falls inside the stated range.
By their numbers in this assay, from the lowest: compounds 4, 2, 3 and 1 (each within the scatter of the next, the first and the last beyond it).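

In this assay, naphthalen-1-yl puts a second six-membered aromatic ring on the saturated chain carbon bound to a sulfur, and the number stays close to those of both bromo compounds: a 1.2-fold lower number from compound 2 to compound 4 (0.08 log units; within the scatter) and a 1.4-fold lower number from compound 3 to compound 4 (0.15 log units; within the scatter). Against the nitro compound the result is the first step in this set to pass the scatter, though only modestly: a 2.0-fold lower number from compound 1 to compound 4 (0.31 log units; beyond the scatter). Nothing measured independently accounts for this step.

Open, going by these compounds, is whether an amine or a carboxylic acid on the aromatic ring would move the number further than any change here. Also open, on these data alone, is what a longer chain between the sulfur and the ring would do, and whether a change away from the thioether arm would have a larger effect than those seen at this position.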